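Thiourea sulfonamide pair: antiproliferative notes toward compound 3

A few compounds are considered here, and "the series" means these few. Any claim that something is new, unique, unknown or untested is made for them only; others in the source may bear on it.

Measured compounds
- compound 1, `COc1cc2ncnc(Nc3ccc(F)cc3)c2cc1OCCCCC(=O)Nc1ccc(S(N)(=O)=O)cc1`: in a functional assay on A549 cells (Homo sapiens) for antiproliferative activity, read by MTT assay, with a stated time of 72 h (a lower number here means a stronger inhibitor, a higher number a weaker inhibitor), compound 1 gives > 40000 nM, a limit of the assay, not a number.
- compound 2, `C#Cc1cccc(Nc2ncnc3ccc(NC(=S)Nc4ccc(S(N)(=O)=O)cc4)cc23)c1`: in this assay compound 2 gives > 40000 nM, again a limit of the assay.

Compound 2 therefore stands at the limit of the assay, and every value shown is a limit (the limit of > 40000 nM in this assay, at which 2 of the 2 values shown sit). Within the data shown here, no step between measured compounds is available, so the series offers no measured direction.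

Compound 3, `NS(=O)(=O)c1ccc(NC(=S)Nc2ccc3ncnc(Nc4cccc(F)c4)c3c2)cc1`, is not yet measured. It differs from compound 2 by fluoro in place of ethynyl on an aromatic carbon. With only limits known for compound 2 and compound 1, nothing indicates that this change moves the number out of the limit region, so no step beyond the scatter is expected. Compound 3 is estimated at 40000 nM, with a range from 10000 nM to 100000 nM, and the expected step from compound 2 is a number no higher from compound 2 to compound 3 (the limit leaves the size open).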

Compound 3, half-maximal inhibitory concentration: 25900 nM
Estimate against measurement, compound 3: 1.5-fold (0.19 log units) above; measured number inside the range.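

In this assay, among these compounds, compound 3 gives 25900 nM, the first value that is a number and not a limit of the assay. The change from 3-ethynylphenyl to 3-fluorophenyl gives an at least 1.5-fold lower number from compound 2 to compound 3 (0.18 log units; that floor lies within the scatter), so a measurable number is compatible with fluoro at this position, but the floor alone does not establish a change beyond the scatter. The true size of the step cannot be read because one end of it is only a limit: the limit of > 40000 nM in this assay, at which 2 of the 3 values shown sit.

Going by these compounds, it remains open whether a chloro or a methoxy group on this aromatic carbon would give a number clearly apart from that of compound 3. A urea in place of the thiourea, with the 3-fluorophenyl group kept, poses the same open question for the linker.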